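From Methyl to Benzyl on the Aromatic Nitrogen

The source may hold more compounds than are shown below. What is called first, only, known or untested is meant among the compounds shown, and "the series" means these compounds.

Three related compounds share one core. Compound 1 `COc1ccc(-c2cc(=O)c3c(OC)cc(OC)cc3[nH]2)cc1` carries a hydrogen on the aromatic nitrogen of that core. In a functional assay on UoC-B1 cells (Homo sapiens) for antiproliferative activity, with a stated time of 72 h (a higher number here means that more compound is needed for the effect, a lower number that less compound is needed), compound 1 gives only a limit of the assay, > 31100 nM. Among the measured compounds shown here, compound 2 `COc1ccc(-c2cc(=O)c3c(OC)cc(OC)cc3n2C)cc1` carries a methyl on that nitrogen, and in this assay compound 2 gives "not determined" (no result reported), so it stands on no number of its own; the only further value shown is the limit of > 31100 nM in this assay, at which 1 of the 2 values shown sits. Compound 3 `COc1ccc(-c2cc(=O)c3c(OC)cc(OC)cc3n2Cc2ccccc2)cc1` differs from compound 2 by phenyl in place of hydrogen on a saturated chain carbon bound to an aromatic nitrogen. For the measured compounds named here, no measured step of this kind exists here, so the size of the change on going from compound 2 to compound 3 cannot be read from the data, and a shift within the usual scatter, in either direction, is as plausible as any other. With the limit of > 31100 nM in this assay, at which 1 of the 2 values shown sits, as the only anchor, compound 3 is expected to be weak as well, estimated at 20000 nM with a range from 3000 nM to 60000 nM.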

Compound 3, half-maximal effective concentration: > 17300 nM
Compound 3 gave a limit, no number (the forecaster's own chance of this, stated with the estimate: 55%); the middle value does not contradict the limit.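

No new step can be read, since compound 1 and compound 3 each give only a limit in this assay, not a number. The compounds shown leave open what concentration either would need in this assay, and whether benzyl in place of hydrogen on the aromatic nitrogen changes it.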